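A few compounds are considered here, and "the series" means these few. Any claim that something is new, unique, unknown or untested is made for them only; others in the source may bear on it.

Compound 1, `Nc1cccc(Nc2nc3ccccc3nc2S(=O)(=O)c2ccccc2)c1`: 2150 nM
Compound 2, `Cc1ccc(S(=O)(=O)c2nc3ccccc3nc2Nc2cccc(N)c2)cc1`: 2000 nM
Compound 3, `COc1ccc(S(=O)(=O)c2nc3ccccc3nc2Nc2cc(OC)cc(OC)c2)cc1`: 6220 nM

All three compounds share a core and were tested in a functional assay on PC-3 cells (Homo sapiens) for cytotoxicity, read by MTT assay, with a stated time of 72 h; on this read-out lower numbers stand for stronger inhibition and higher numbers for weaker inhibition. Compound 3 stands highest of the three numbers, and so is the weakest of the three in this assay; compound 1 lies nearer to it and compound 2 furthest away, both steps lying beyond the scatter.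

The unmeasured compound 4, `COc1ccc(S(=O)(=O)c2nc3ccccc3nc2Nc2cccc(N)c2)cc1`, comes from compound 3 through one change: 3-aminophenyl in place of 3,5-dimethoxyphenyl on a nitrogen on an aromatic ring. With this change, compound 4 carries the same 3-aminophenyl as compounds 1 and 2 and otherwise matches compound 3. Among the compounds with values here, the only measured step that bears on it is a 1.1-fold lower number from compound 1 to compound 2 (0.03 log units; within the scatter), which shows that swapping the substituent on the other aromatic ring hardly moves the number in this assay. Compound 3, which carries 3,5-dimethoxyphenyl instead of 3-aminophenyl, is the one that stands apart. The expectation is therefore that returning to 3-aminophenyl brings compound 4 back down to where compounds 1 and 2 sit, as a step of a 3.0-fold lower number from compound 3 to compound 4 (0.47 log units; beyond the scatter) beyond the scatter. Compound 4 is estimated at 2100 nM, with a range from 1000 nM to 4500 nM.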

Compound 4, half-maximal inhibitory concentration: 8600 nM
Beside the measured number, compound 4's estimate is 4.1-fold (0.61 log units) below it; measured number above the stated range.
By their numbers in this assay, from the lowest: compounds 2 and 1 (each within the scatter of the next); then compounds 3 and 4 (each within the scatter of the next).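

In this assay, replacing 3,5-dimethoxyphenyl with 3-aminophenyl on a nitrogen on an aromatic ring gives a 1.4-fold higher number from compound 3 to compound 4 (0.14 log units; within the scatter), so with methoxy present elsewhere in the molecule, these two groups cannot be told apart at this position. The change that does register is on an aromatic carbon: methoxy in place of methyl gives a 4.3-fold higher number from compound 2 to compound 4 (0.63 log units; beyond the scatter), and methoxy in place of hydrogen gives a 4.0-fold higher number from compound 1 to compound 4 (0.60 log units; beyond the scatter), both modest steps, while methyl in place of hydrogen gave only a 1.1-fold lower number from compound 1 to compound 2 (0.03 log units; within the scatter). At that carbon, then, hydrogen and methyl sit together and methoxy stands apart on the weaker side, and no measurement at hand explains this difference.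

The swap between 3-aminophenyl and 3,5-dimethoxyphenyl is shown only alongside methoxy, so it remains open whether it would stay as small with hydrogen or methyl on that aromatic carbon. Going by these compounds, it is also open whether a larger ether such as ethoxy, or a fluorine, chlorine or hydroxyl group at the same place, would follow methoxy or stay with hydrogen and methyl.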